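Triazolyl for sulfamoyl: metabolic stability outlook

The compounds below may be only part of what the source reports. "The series", "measured", "known", "first", "only" and "open" are said of these compounds alone.

Compound 1 `COc1ccc(-c2cc(-c3ccc(S(N)(=O)=O)cc3)cnc2N)cn1` is characterised in an in vitro ADME assay on microsomes from liver (Homo sapiens) for metabolic stability; on this read-out lower numbers stand for a shorter-lived compound and higher numbers for a longer-lived compound. In this assay compound 1 gives > 4.16 h, which is a limit of the assay and not a number. Compound 2 `COc1ccc(-c2cc(-c3ccc(S(C)(=O)=O)c(F)c3)cnc2N)cn1` gives > 4.16 h in this assay, again a limit. Both measured values thus sit at the limit of > 4.16 h in this assay, at which 2 of the 2 values shown sit. Compound 3 `COc1ccc(-c2cc(-c3ccc(-n4cncn4)cc3)cnc2N)cn1` is not yet measured; it differs from compound 1 by 1H-1,2,4-triazol-1-yl in place of sulfamoyl on an aromatic carbon. Going by the values given here, with no measured step between compounds available, the expected change is an at least 1.1-fold lower number from compound 1 to compound 3 (0.07 log units; that floor lies within the scatter), nothing beyond the scatter. Compound 3 is estimated at 3.5 h in this assay, within 1.5 h to 8 h, with a fair chance that only a limit is again reported.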

Compound 3, half-life: 3.5 h
For compound 3 middle estimate and measured number coincide at the digits printed, within the range that was stated.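

With compound 3, the series gains its first read-out in this assay that is a number and not a limit. Placing 1H-1,2,4-triazol-1-yl for sulfamoyl on the aromatic carbon para to a large group gives an at least 1.1-fold lower number from compound 1 to compound 3 (0.07 log units; that floor lies within the scatter) and so fixes only a floor, with no change beyond the scatter shown. Compound 1 remains a limit, and the true size of the step stays unread: the limit of > 4.16 h in this assay, at which 2 of the 3 values shown sit.

On these data alone, whether a carboxylic acid or an amine in this place would give a different half-life in this assay stays open. Also open, as far as these compounds go, is whether other five-membered aromatic rings, such as an imidazole or a tetrazole, would behave like 1H-1,2,4-triazol-1-yl.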